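The compounds below may be only part of what the source reports. "The series", "measured", "known", "first", "only" and "open" are said of these compounds alone.

In a functional assay (Homo sapiens) for antiproliferative activity, read by resazurin assay, with a stated time of 48 h, tested at 5 uM (a higher number here means a stronger effect of the compound at the concentration tested, a lower number a weaker effect), compound 2 `COc1cc(OC)c2c(=O)cc(-c3ccc(OCCN4CCCC4=O)cc3)oc2c1` gives 7%. Compound 3 `COc1cc(OC)c2c(=O)cc(-c3ccc(OCCN)cc3)oc2c1` gives 6%, and the step of a number 1 percentage points lower from compound 2 to compound 3 (within the scatter) shows that these two numbers lie within the scatter of each other. Compound 1 `COc1cc(OC)c2c(=O)cc(-c3ccc(OCCF)cc3)oc2c1` is reported only as "not active" (no number reported), with no number. Compound 4 `COc1cc(OC)c2c(=O)cc(-c3ccc(OCCCN)cc3)oc2c1` differs from compound 3 by aminomethyl in place of amino on a saturated chain carbon, two bonds along the chain from an oxygen on an aromatic ring. Among the compounds with values here, no measured pair lengthens this chain; the one measured step, a number 1 percentage points lower from compound 2 to compound 3 (within the scatter), exchanged groups at the same place without moving the number beyond the scatter, so it bears only loosely on the change here. With nothing pointing either way, compound 4 is estimated at 6%, in a range from 0% to 16%. The step of no change at the digits printed from compound 3 to compound 4 (within the scatter) is expected to be none beyond the scatter.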

Compound 4, a percentage reported as inhibition, at one concentration (the size of the read-out at that concentration, not a potency): 22%
Compound 4: the middle estimate sits 16 percentage points below what was measured, outside the stated range (above it).
By their numbers in this assay, from the lowest: compounds 3 and 2 (each within the scatter of the next); then compound 4.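

Extending 2-aminoethoxy to 3-aminopropoxy matters at this position: in this assay this change gives a number 16 percentage points higher from compound 3 to compound 4 (beyond the scatter). The earlier step between compound 2 and compound 3 stayed within the scatter. Exchanging the 2-oxopyrrolidin-1-yl group for aminomethyl at the same place gives a number 15 percentage points higher from compound 2 to compound 4 (beyond the scatter) so the amine on the longer chain stands apart from both shorter-chain neighbours. Nothing measured here accounts for the effect of the added carbon.

Still open, on these data alone, is whether a longer chain such as 4-aminobutoxy would raise the number further. Also open, as far as these compounds go, is whether a dimethylamino group or a carboxylic acid could take the place of the amine at the chain end.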